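The source may hold more compounds than are shown below. What is called first, only, known or untested is meant among the compounds shown, and "the series" means these compounds.

Measured in a functional assay on MCF-10A cells (Homo sapiens) for antiproliferative activity, with a stated time of 48 h; on this read-out lower numbers stand for an effect already at smaller amounts and higher numbers for an effect only at larger amounts of compound:
- Compound 1 `COc1ccc2nc(C)cc(NCc3ccccc3)c2c1`: 28600 nM
- Compound 2 `COc1ccc2nc(C)cc(NCc3ccncc3)c2c1`: 41600 nM
- Compound 3 `COc1ccc2nc(C)cc(NCc3ccc(C)cc3)c2c1`: 22400 nM

Compound 3 stands within the usual scatter of both other compounds, so the three values cannot be ranked with confidence. The next compound, compound 4 `COc1ccc2nc(C)cc(NCc3cccc(F)c3)c2c1`, differs from compound 3 at one place: 3-fluorophenyl in place of 4-methylphenyl on a saturated chain carbon bound to a nitrogen on an aromatic ring.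

For the measured compounds named here, no measured compound carries a 3-fluorophenyl group, so the data offer no direct precedent for this change. The closest evidence comes from the other changes to the group at this place: a 1.3-fold lower number from compound 1 to compound 3 (0.11 log units; within the scatter), a 1.9-fold lower number from compound 2 to compound 3 (0.27 log units; within the scatter) and a 1.5-fold higher number from compound 1 to compound 2 (0.16 log units; within the scatter). All three steps stay within the scatter, so swapping this group has not yet moved the number measurably in compounds 1, 2 and 3. The same is expected here, with no step beyond the scatter in this assay and no firm direction.

The expected step is a 1.2-fold higher number from compound 3 to compound 4 (0.08 log units; within the scatter). Compound 4 is estimated at 27000 nM, with an expected range from 14000 nM to 50000 nM.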

Compound 4, half-maximal effective concentration: 14700 nM
Compound 4: the middle estimate sits 1.8-fold (0.26 log units) above what was measured; the range from low to high includes it.
By their numbers in this assay, from the lowest: compounds 4, 3, 1 and 2 (each within the scatter of the next, the first and the last beyond it).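

Within this assay this position now gives its first step beyond the usual scatter: the change of pyridin-4-yl to 3-fluorophenyl shows up as a 2.8-fold lower number from compound 2 to compound 4 (0.45 log units; beyond the scatter) and so does register, if only modestly. The other two steps, a 1.5-fold lower number from compound 3 to compound 4 (0.18 log units; within the scatter) and a 1.9-fold lower number from compound 1 to compound 4 (0.29 log units; within the scatter) do not separate compound 4 from compound 3 or compound 1, so 3-fluorophenyl cannot be ranked above 4-methylphenyl or plain phenyl. For the compounds shown here, the one firm difference at this place so far therefore lies between 3-fluorophenyl and pyridin-4-yl.

Nothing at hand explains that difference. On these data alone, it also stays open whether an amine or a carboxylic acid in place of the fluoro, or a longer chain at this place, would move the number further, and in which direction.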